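Adding Chlorine to the Fluorophenyl Group: Expected Potency

This account rests on a few compounds, and the source may have more. Where it says the series, first, only, none or still open, it means among the compounds named here.

Three compounds share one core and differ only in the substituted phenyl group on a nitrogen on an aromatic ring. In a functional assay on MDA-MB-231 cells (Homo sapiens) for inhibition, read by MTT assay, with a stated time of 72 h (a higher number here means a weaker inhibitor, a lower number a stronger inhibitor), compound 1 `C=CC(=O)Nc1cccc(NC(=O)CSc2nc(Nc3cccc(F)c3)c3ccccc3n2)c1` gives 8160 nM, compound 2 `C=CC(=O)Nc1cccc(NC(=O)CSc2nc(Nc3cccc(Cl)c3)c3ccccc3n2)c1` gives 16300 nM, and compound 3 `C=CC(=O)Nc1cccc(NC(=O)CSc2nc(Nc3ccc(F)cc3)c3ccccc3n2)c1` gives 9490 nM. Compound 3 stands second highest of these three numbers, but the step of a 1.2-fold higher number from compound 1 to compound 3 (0.07 log units; within the scatter) and the step of a 1.7-fold lower number from compound 2 to compound 3 (0.23 log units; within the scatter) both lie within the scatter. Compound 4 `C=CC(=O)Nc1cccc(NC(=O)CSc2nc(Nc3ccc(F)c(Cl)c3)c3ccccc3n2)c1` differs from compound 3 by chloro in place of hydrogen on an aromatic carbon. Among the compounds with values here, the only measured step that bears on this change is a 2.0-fold higher number from compound 1 to compound 2 (0.30 log units; within the scatter), which also lies within the scatter. In this assay no shift beyond the scatter is therefore expected, and the estimated step is a 1.3-fold higher number from compound 3 to compound 4 (0.10 log units; within the scatter). Compound 4 is expected to give 12000 nM, within a range from 5000 nM to 30000 nM.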

Compound 4, half-maximal inhibitory concentration: 10600 nM
Compound 4: the middle estimate sits 1.1-fold (0.05 log units) above what was measured; low and high end bracket the measured number.
By their numbers in this assay, from the lowest: compounds 1, 3, 4 and 2 (each within the scatter of the next).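

In this assay, chloro on the aromatic carbon ortho to the fluoro group leaves the number within the scatter (a 1.1-fold higher number from compound 3 to compound 4 (0.05 log units; within the scatter)). Seen from the other side, fluoro in place of hydrogen on the 3-chlorophenyl group also stays within the scatter (a 1.5-fold lower number from compound 2 to compound 4 (0.19 log units; within the scatter)), as does the swap from 3-fluorophenyl to 3-chloro-4-fluorophenyl (a 1.3-fold higher number from compound 1 to compound 4 (0.11 log units; within the scatter)). So this ring carries both halogens with no shift beyond the scatter, and nothing measured here offers a reason for that.

Still open, going by these compounds, is whether a methoxy group, an amine or a carboxylic acid in place of the chloro would also leave the number within the scatter.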